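A Second Methyl on the Amide Nitrogen

This account rests on a few compounds, and the source may have more. Where it says the series, first, only, none or still open, it means among the compounds named here.

In an ADME assay on L929 cells (Mus musculus) for cytotoxicity, read by resazurin assay, with a stated time of 48 h (on this read-out lower numbers stand for higher toxicity in this test and higher numbers for lower toxicity in this test), compound 1 `O=C(O)CCn1c2ccc([N+](=O)[O-])cc2c(=O)n1Cc1ccccc1` gives > 256000 nM as a limit. Compound 2 `O=C(O)CCCn1c2ccc([N+](=O)[O-])cc2c(=O)n1Cc1ccccc1` gives > 256000 nM as a limit too. Compound 3 `CNC(=O)CCCn1c2ccc([N+](=O)[O-])cc2c(=O)n1Cc1ccccc1` gives > 256000 nM as a limit as well. That leaves compound 3 at the limit of > 256000 nM in this assay, at which 3 of the 3 values shown sit, with no exact number to start from. Compound 4 `CN(C)C(=O)CCCn1c2ccc([N+](=O)[O-])cc2c(=O)n1Cc1ccccc1` has methyl in place of hydrogen on an amide-type nitrogen. The closest measured step is a step that the two limits leave unreadable from compound 2 to compound 3 and the two chain steps a step that the two limits leave unreadable from compound 1 to compound 2 and a step that the two limits leave unreadable from compound 1 to compound 3 fare no better, so none offers a size to carry over. In this assay no change beyond the usual scatter is therefore expected, and the expected step is a number no higher from compound 3 to compound 4 (the limit leaves the size open) in neither direction. Compound 4 is estimated at 256000 nM with an expected range from 128000 nM to 512000 nM and will probably be reported as a limit again.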

Compound 4, concentration lethal to 50% of the cells: > 256000 nM
Compound 4 was reported as a limit (the forecaster's own chance of this, stated with the estimate: 85%); the middle value sits exactly at the limit.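

No step among compound 1, compound 2, compound 3 and compound 4 can be read, since all four stop at one limit: the limit of > 256000 nM in this assay, at which 4 of the 4 values shown sit.

The compounds shown leave open what exact lethal concentration any of them has in this assay, and whether these chain and amide changes alter it at all.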